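The source may hold more compounds than are shown below. What is called first, only, known or untested is meant among the compounds shown, and "the series" means these compounds.

Going by the values given here, compound 3, `Clc1ccccc1Cn1nnc2c(NC3CCCCC3)nc(-c3ccccc3)nc21`, gives the highest of the three numbers so far in an assay on isolated protein for binding affinity to adenosine receptor A1 (Bos taurus); on this read-out higher numbers stand for weaker inhibition and lower numbers for stronger inhibition. Among the compounds with values here, compound 1, `CC(O)CNc1nc(-c2ccccc2)nc2c1nnn2Cc1ccccc1Cl`, gives 32000000 nM, and compound 3 gives 34000000 nM; the step of a 1.1-fold higher number from compound 1 to compound 3 (0.03 log units; within the scatter) is the only single-place step among the measured compounds. Within the data shown here, compound 2, `OC1CCC(Nc2nc(-c3ccccc3)nc3c2nnn3Cc2ccccc2F)CC1`, stands apart with 1850000 nM, and it differs from compound 3 in two places, so no single step connects them.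

The unmeasured compound 4, `OC1CCC(Nc2nc(-c3ccccc3)nc3c2nnn3Cc2ccccc2Cl)CC1`, differs from compound 3 by hydroxy in place of hydrogen on a saturated ring carbon. Among the measured compounds shown here, no measured step carries exactly this change. The step from compound 1 to compound 3 shows that a hydroxy-bearing chain and a plain cyclohexyl ring gave numbers within the scatter of each other. Compound 2, which carries the same 4-hydroxycyclohexyl group as compound 4 but a fluoro in place of the chloro on the other ring, gives a number well below that of compound 3, which points toward a lower number for compound 4, though the two changes cannot be separated. Compound 4 is therefore expected to show a step of a 6.8-fold lower number from compound 3 to compound 4 (0.83 log units; beyond the scatter) in this assay. Compound 4 is estimated at 5000000 nM, with a range from 1500000 nM to 20000000 nM.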

Compound 4, inhibition constant: 3100000 nM
Compound 4: the middle estimate sits 1.6-fold (0.21 log units) above what was measured, within the range that was stated.
By their numbers in this assay, from the lowest: compounds 2 and 4 (each within the scatter of the next); then compounds 1 and 3 (each within the scatter of the next).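

In this assay the hydroxy on a saturated ring carbon, three ring bonds from the ring atom that bears the large group, is the first single change shown to move the number beyond the scatter (an 11-fold lower number from compound 3 to compound 4 (1.04 log units; beyond the scatter)). A hydroxy on the group at the nitrogen does not by itself go with the lower number: compound 1 goes against that, since its 2-hydroxypropyl group sits within the scatter of the plain cyclohexyl (a 1.1-fold higher number from compound 1 to compound 3 (0.03 log units; within the scatter)) and the 4-hydroxycyclohexyl group stands clearly apart from it (a 10-fold lower number from compound 1 to compound 4 (1.01 log units; beyond the scatter)). With the 4-hydroxycyclohexyl group in place, chloro and fluoro on the aromatic carbon cannot be told apart here (a 1.7-fold higher number from compound 2 to compound 4 (0.22 log units; within the scatter)).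

No measurement is at hand that explains this change. On these data alone, whether a methoxy, an amine or a carboxylic acid on the same ring carbon would give a step like that of the hydroxy stays open, as does the effect of a longer chain carrying the hydroxy.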